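A few compounds are considered here, and "the series" means these few. Any claim that something is new, unique, unknown or untested is made for them only; others in the source may bear on it.

Measured so far in a physicochemical assay for solubility, at pH 7.4; a higher number here means a more soluble compound, a lower number a less soluble compound:

- compound 1 `NS(=O)(=O)c1ccc(S(=O)(=O)CCO)c(F)c1`: 3300 ug/mL
- compound 2 `Nc1cc(S(N)(=O)=O)ccc1S(=O)(=O)CCCO`: 8400 ug/mL
- compound 3 `CC(=O)OCCCCc1ccc(S(N)(=O)=O)cc1`: 800 ug/mL

Of these three, compound 3 stands lowest, at 800 ug/mL. Compound 1 is its nearest neighbour and compound 2 its furthest, and both gaps lie beyond the usual scatter of repeated measurements. Among the compounds with values here, the three structures differ in more than one place, so no pair among them isolates a single change, and their values can only be set side by side.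

Compound 4 `CC(=O)OCCCCCc1ccc(S(N)(=O)=O)cc1` has not been measured yet. It departs from compound 3 in one place: acetoxymethyl in place of acetoxy on a saturated chain carbon, four bonds along the chain from an aromatic carbon. In words, acetoxymethyl stands in place of acetoxy on a saturated chain carbon, four bonds along the chain from an aromatic carbon.

Within the data shown here, no measured pair shows this kind of change, so the expectation rests on the small size of the change and on the starting point, compound 3 at 800 ug/mL. A modest fall in this assay is expected, close to the edge of the scatter, and the estimated step is a 2.3-fold lower number from compound 3 to compound 4 (0.36 log units; beyond the scatter). For compound 4 the estimated value is 350 ug/mL, with an expected range of 150 ug/mL to 800 ug/mL.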

Compound 4, solubility: 1200 ug/mL
Beside the measured number, compound 4's estimate is 3.4-fold (0.54 log units) below it; measured number above the stated range.
By their numbers in this assay, from the lowest: compounds 3 and 4 (each within the scatter of the next); then compound 1; then compound 2.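

Within the data shown here, this pair gives the first reading in the set of a single change, since compounds 1, 2 and 3 differ from one another in more than one place. In this assay, acetoxymethyl in place of acetoxy on a saturated chain carbon, four bonds along the chain from an aromatic carbon, gives a 1.5-fold higher number from compound 3 to compound 4 (0.18 log units; within the scatter) and so stays within the ordinary spread of repeat measurements, which means this pair shows no measurable effect of the change at this position. No supporting data bear on why the two values lie so close together.

A single pair cannot show whether the same holds as the chain grows, so a longer chain carrying the same acetate ester end would test whether the read-out stays this flat or eventually moves clearly away from compound 3. As far as these compounds go, it also remains open how far the read-out would shift if a different group, such as an amine or a carboxylic acid, replaced the acetate ester at the end of this chain while the rest of the structure stayed the same.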